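The source may report more compounds than this note shows. Statements on the series, on what has been measured and on what is new or still open speak of the compounds shown alone.

Values in an ADME assay on HepG2 cells (Homo sapiens) for inhibition, with a stated time of 48 h; a lower number here means that less compound is needed, a higher number that more compound is needed for the effect:

- Compound 1 `COc1ccc(Nc2ncc3c(N4CCN(C)CC4)cccc3n2)cc1`: > 40000 nM, a limit of the assay.
- Compound 2 `CNc1nc(Nc2ccc(F)cc2)nc2ccccc12`: 16200 nM.
- Compound 3 `Brc1ccc(Nc2nc(NCc3ccco3)c3ccccc3n2)cc1`: 19000 nM.

Within the data shown here, compound 3 has a number within the scatter of the number for compound 2, and these are the only two numbers in the set. Among the measured compounds shown here, no measured pair differs in one place only, so the series gives no direct guide to the size of the next step.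

Compound 4 `CC(O)c1ccc(Nc2nc(NCc3ccco3)c3ccccc3n2)cc1` has 1-hydroxyethyl in place of bromo on an aromatic carbon.

A small move towards a higher number in this assay is expected, with the estimated 1.3-fold higher number from compound 3 to compound 4 (0.10 log units; within the scatter) staying near the scatter. The expected value for compound 4 is 24000 nM, with an estimated range of 11000 nM to 40000 nM.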

Compound 4, half-maximal effective concentration: 12600 nM
Estimate against measurement, compound 4: 1.9-fold (0.28 log units) above; the range from low to high includes it.
By their numbers in this assay, from the lowest: compounds 4, 2 and 3 (each within the scatter of the next). At a limit, above all of these: compound 1.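

In this assay, the first pair differing in one place gives a 1.5-fold lower number from compound 3 to compound 4 (0.18 log units; within the scatter). Exchanging 4-bromophenyl for 4-(1-hydroxyethyl)phenyl therefore brings in a hydrogen-bond donor and acceptor on the aromatic carbon para to a large group, while the step stays within the scatter. No available measurement of a property bears on this step.

On these data alone, whether an amine or a carboxylic acid at this position would give a step beyond the scatter remains open. So does the effect of a longer chain there.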